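A Hydroxyl on the Pyrrolidine Ring: Expected Affinity

The source may report more compounds than this note shows. Statements on the series, on what has been measured and on what is new or still open speak of the compounds shown alone.

Of the compounds shown here, two with a shared core have been measured in an assay on isolated protein for binding affinity to melanin-concentrating hormone receptor 1 (Homo sapiens); on this read-out lower numbers stand for stronger inhibition and higher numbers for weaker inhibition. Compound 1, `CN1CCN(CCCN(c2nc3cc(F)c(F)cc3[nH]2)[C@@H]2CC[C@]3(c4cccc(C=O)c4)C[C@@H]3C2)CC1`, gives 16.3 nM. Compound 2, `CN1CCN(CCCN(c2nc3cc(F)c(F)cc3[nH]2)[C@@H]2CC[C@]3(c4cccc(CN5CCCC5)c4)C[C@@H]3C2)CC1`, gives 25.7 nM, the higher of the two numbers, though the step of a 1.6-fold higher number from compound 1 to compound 2 (0.20 log units; within the scatter) lies within the scatter, so the two compounds stand together. Compound 3, `CN1CCN(CCCN(c2nc3cc(F)c(F)cc3[nH]2)[C@@H]2CC[C@]3(c4cccc(CN5CC[C@H](O)C5)c4)C[C@@H]3C2)CC1`, has not yet been measured. It differs from compound 2 by hydroxy in place of hydrogen on a saturated ring carbon, two ring bonds from the ring nitrogen. For the measured compounds named here, the only step at hand, a 1.6-fold higher number from compound 1 to compound 2 (0.20 log units; within the scatter), altered the same group on the aromatic carbon and still stayed within the scatter. On that basis no step beyond the scatter is expected in this assay, and the expected step is a 1.0-fold lower number from compound 2 to compound 3 (0.01 log units; within the scatter). Compound 3 is accordingly estimated at 25 nM, with a range from 10 nM to 65 nM.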

Compound 3, inhibition constant: 441 nM
Estimate against measurement, compound 3: 18-fold (1.25 log units) below; the measured number lies above the stated range.
By their numbers in this assay, from the lowest: compounds 1 and 2 (each within the scatter of the next); then compound 3.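

In this assay the outer ring of the (pyrrolidin-1-yl)methyl group proves sensitive to a very small change: a hydroxy two ring bonds from the ring nitrogen, just 1 heavy atom, gives a 17-fold higher number from compound 2 to compound 3 (1.23 log units; beyond the scatter) and so moves the number well beyond the scatter. Replacing formyl with (pyrrolidin-1-yl)methyl had stayed within the scatter, whereas replacing it with (3-hydroxypyrrolidin-1-yl)methyl gives a 27-fold higher number from compound 1 to compound 3 (1.43 log units; beyond the scatter) and thus shows that, among these compounds, the large loss appears only once the hydroxy is present. No measurement at hand explains this loss.

Whether it depends on the hydroxy's spatial arrangement remains open, since only one stereoisomer is shown. Also open, from the compounds shown here alone, is how a methoxy, a fluorine or a primary amine on the same ring carbon would compare.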